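The compounds below may be only part of what the source reports. "The series", "measured", "known", "first", "only" and "open" are said of these compounds alone.

Compound 2 `Cc1cc(C)n(-c2ccc(S(=O)(=O)NC(=O)NNC(=N)N)cc2)n1` sits in a small group of three sulfonyl-linked compounds examined in a functional assay on the whole organism (blood, strain albino) with Mus musculus as the target, with stated times of 6 days and 4 h, at a dose of 0.4 mmol/kg by the oral route (a lower number here means less inhibition, a higher number more inhibition at the dose given (going by the name of the read-out)), where it gives 3%. Its two companions give values that lie within the usual scatter of this one: compound 1 `Cc1cc(C(=O)O)nn1-c1ccc(S(=O)(=O)NC(=S)NC2CCCCC2)cc1` gives 1% in this assay, and compound 3 `Cc1cc(C)n(-c2ccc(S(=O)(=O)NC(=S)NCc3ccccc3)cc2)n1` gives 0% in this assay. The three numbers therefore cannot be told apart, and none of them can be said to be higher or lower than another; all three numbers stand low on the read-out at the dose given.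

Compound 4 `CCCCNC(=O)NS(=O)(=O)c1ccc(-n2nc(C)cc2C)cc1` has not yet been measured in this assay. It differs from compound 2 in one place, where (a group of 4 heavy atoms (4 carbon; no ring) in place of a group of 4 heavy atoms (1 carbon, 3 nitrogen; no ring), on an amide-type nitrogen). For the measured compounds named here, no step between two measured compounds is available for this or any other change, so no direction can be read from the existing numbers.

With every measured value close to the bottom of the read-out, compound 4 is expected to stay there as well, and the expected step from compound 2 no change at the digits printed from compound 2 to compound 4 (within the scatter) is none beyond the scatter. The estimate for compound 4 in this assay is 3%, with a range from 0% to 12%.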

Compound 4, a percentage reported as inhibition, in the whole organism at one dose (the size of the read-out at that dose, not a potency): 2%
Compound 4: middle estimate off by 1 percentage points, on the high side; measured number inside the range.
By their numbers in this assay, from the lowest: compounds 3, 1, 4 and 2 (each within the scatter of the next).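

For the compounds shown here, the step of a number 1 percentage points lower from compound 2 to compound 4 (within the scatter) is the first in this assay between two compounds that differ in one place, and it concerns the amide-type nitrogen whose other neighbour is the carbonyl carbon. Butyl, with 0 hydrogen-bond donors and 0 hydrogen-bond acceptors, stands there in place of a group of 4 heavy atoms (1 carbon, 3 nitrogen) with 3 hydrogen-bond donors and 1 hydrogen-bond acceptor, yet the two compounds cannot be told apart, so this large difference in what the group carries gives no readable difference at the dose given. Going by these compounds alone, since both numbers lie close to the bottom of the read-out, the step shows only that neither group lifts the compound from there, and no measured property bears on this result.

From the compounds shown here alone, it remains open whether any group at this place would raise the read-out clearly, for instance a longer chain such as octyl, or a butyl chain ending in a carboxylic acid or an amine. With a single dose in view, the numbers also leave open whether compound 2 and compound 4 would stay alike at a higher dose.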